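The compounds below may be only part of what the source reports. "The series", "measured", "known", "first", "only" and "open" are said of these compounds alone.

Measured compounds:
compound 1, `Cc1cccc(-c2noc(C3CN(S(=O)(=O)c4ccc(Cl)cc4)C3)n2)c1`: 1100 nM
compound 2, `O=C(C1CCCCC1)N1CC(c2nc(-c3cccc(F)c3)no2)C1`: > 10000 nM
compound 3, `O=C(C1CCC2(CCC2)CC1)N1CC(c2nc(-c3cccc(Cl)c3)no2)C1`: > 10000 nM

These three compounds share a core, and they differ in the group attached to the ring nitrogen and in the halogen on the aromatic ring. Going by the values given here, in an assay on HEK293 cells for negative allosteric modulation of metabotropic glutamate receptor 5 (Homo sapiens), read by FLIPR (a higher number here means a weaker inhibitor, a lower number a stronger inhibitor), compound 1 gives 1100 nM, the only plain number among the three. For compound 2 the result is only a limit of the assay, > 10000 nM. For compound 3 the result is likewise only a limit, > 10000 nM. Among the compounds with values here, compound 3 therefore stands at the limit of > 10000 nM in this assay, at which 2 of the 3 values shown sit, the weak end of what these numbers show, and no step between two measured compounds can be given here.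

Compound 4, `O=C(c1ccccc1F)N1CC(c2nc(-c3cccc(Cl)c3)no2)C1`, comes from compound 3 by a group of 7 heavy atoms (6 carbon, 1 fluorine; one six-membered aromatic ring of carbon only) in place of a group of 9 heavy atoms (9 carbon; one four-membered non-aromatic ring of carbon only, one six-membered non-aromatic ring of carbon only), on a carbonyl carbon. Since compound 3 sits at a limit, only the direction can be judged: a move toward stronger inhibition is expected, and it is expected to be larger than the usual scatter, as the step of an at least 3.3-fold lower number from compound 3 to compound 4 (0.52 log units; beyond the scatter) in this assay expresses. For compound 4 the expected value in this assay is 3000 nM, with a range from 800 nM to 10000 nM, and it remains possible that only a limit is reported again.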

Compound 4, half-maximal inhibitory concentration: 670 nM
Compound 4: the middle estimate sits 4.5-fold (0.65 log units) above what was measured; the measured number lies below the stated range.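

On the carbonyl carbon bound to the amide-type nitrogen in a ring, 2-fluorophenyl replaces a group of 9 carbon atoms with a four-membered and a six-membered non-aromatic ring, and in this assay this gives an at least 14-fold lower number from compound 3 to compound 4 (1.17 log units; beyond the scatter). Going by these compounds alone, this is the first comparison here that changes one place only, and it shows that the group on this carbonyl carbon alone can move the result well beyond the scatter, with compound 4 giving a plain number of 670 nM. The step is stated as a minimum because compound 3 has only a limit of the assay, so the real gap could be larger: the limit of > 10000 nM in this assay, at which 2 of the 4 values shown sit.

Since the whole group changes at once, these compounds cannot separate the part played by the aromatic ring from that of its fluorine, and a plain phenyl or a pyridine ring on the same carbonyl carbon would help to tell these apart. On these data alone, it also remains open whether 2-fluorophenyl would have a similar effect with fluorine in place of chlorine on the aromatic ring at the other end of the molecule, as in compound 2.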